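Removing one methyl from the dimethoxy analogue

A few compounds are considered here, and "the series" means these few. Any claim that something is new, unique, unknown or untested is made for them only; others in the source may bear on it.

The compounds here share one core and differ only in the aromatic ring that hangs off it. Compound 1 `O=CCN1N=C(c2ccc3ccccc3c2)CC1c1ccccc1` gives 7400 nM in a functional assay on PC-3 cells (Homo sapiens) for cytotoxicity, read by sulforhodamine B assay, with a stated time of 48 h; on this read-out lower numbers stand for stronger inhibition and higher numbers for weaker inhibition. Among the measured compounds shown here, compound 2 `O=CCN1N=C(c2ccc3ccccc3c2)CC1c1cccc([N+](=O)[O-])c1` gives 2980 nM in this assay, and the only measured single step, a 2.5-fold lower number from compound 1 to compound 2 (0.40 log units; beyond the scatter), shows that a nitro group on that ring lowers the number. Compound 3 `COc1ccc(C2CC(c3ccc4ccccc4c3)=NN2CC=O)cc1OC` gives 1980 nM, the lowest of the three numbers, although its gap to compound 2 lies within the scatter; only its gap to compound 1 lies beyond it.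

Compound 4 `COc1ccc(C2CC(c3ccc4ccccc4c3)=NN2CC=O)cc1O` is the next compound, not yet measured. It differs from compound 3 by hydrogen in place of methyl on an oxygen on an aromatic ring. For the measured compounds named here, none of the measured steps concerns a methoxy or hydroxy group, so the nitro step gives no guide to this change, and the two methoxy groups of compound 3 were never varied one at a time. With nothing that bears directly on it, the expectation is a step no larger than the usual scatter, in either direction, so that compound 4 is expected to stay near compound 3 with a 1.3-fold higher number from compound 3 to compound 4 (0.10 log units; within the scatter). Compound 4 is therefore estimated at 2500 nM in this assay, within a range from 1000 nM to 6500 nM.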

Compound 4, half-maximal inhibitory concentration: 2040 nM
Compound 4: middle estimate off by 1.2-fold (0.09 log units), on the high side, and the stated range covers the measured number.
By their numbers in this assay, from the lowest: compounds 3, 4 and 2 (each within the scatter of the next); then compound 1.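

In this assay, among the compounds shown here, the change from methoxy to hydroxy on the aromatic ring gives the first measured step at this oxygen (a 1.0-fold higher number from compound 3 to compound 4 (0.01 log units; within the scatter)), and that step lies within the scatter, so in this pair the methyl can be lost without any visible change in the number. The 3-hydroxy-4-methoxyphenyl group also cannot be told apart from 3-nitrophenyl (a 1.5-fold lower number from compound 2 to compound 4 (0.16 log units; within the scatter)), whereas putting it in place of plain phenyl gives a step beyond the scatter (a 3.6-fold lower number from compound 1 to compound 4 (0.56 log units; beyond the scatter)), so compound 4 joins compound 2 and compound 3 in standing clear of compound 1. No outside measurement is available to explain why this swap leaves the number where it is.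

Still open, going by these compounds, is whether the remaining methoxy group of compound 4 would bear the same change, and whether a longer chain on this oxygen, or an amine in its place, would keep the number. Also open, on these data alone, is whether a carboxylic acid on the aromatic ring would fit the same picture in this assay or break it.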